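Para-fluoro swap on a cinnamamide thiadiazole: expecting little change

This account rests on a few compounds, and the source may have more. Where it says the series, first, only, none or still open, it means among the compounds named here.

Of the compounds shown here, two sharing one core have been measured. Compound 1 `Cc1ccc(-c2nnc(NC(=O)/C=C/c3ccc(C(F)(F)F)cc3)s2)cc1` carries a trifluoromethyl group on the outer ring, and compound 2 `Cc1ccc(-c2nnc(NC(=O)/C=C/c3ccccc3)s2)cc1` carries a hydrogen there instead. In a functional assay on MCF7 cells (Homo sapiens) for antiproliferative activity, read by MTT assay, with a stated time of 48 h (on this read-out lower numbers stand for stronger inhibition and higher numbers for weaker inhibition), compound 1 gives 1.1 ug/mL, and in this assay compound 2 gives 1.19 ug/mL. Compound 2 stands alongside compound 1 rather than apart from it: the step of a 1.1-fold higher number from compound 1 to compound 2 (0.03 log units; within the scatter) shows that removing the trifluoromethyl group did not move the number beyond the scatter.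

Compound 3 `Cc1ccc(-c2nnc(NC(=O)/C=C/c3ccc(F)cc3)s2)cc1` is the next compound, not yet measured. It differs from compound 2 by fluoro in place of hydrogen on an aromatic carbon, so the position that held trifluoromethyl in compound 1 now holds a smaller single-atom group. Among the compounds with values here, the one step that bears on this is a 1.1-fold higher number from compound 1 to compound 2 (0.03 log units; within the scatter), which showed that a group at this place, or none, made no difference beyond the scatter. A step of similar size is therefore expected for a 1.0-fold lower number from compound 2 to compound 3 (0.01 log units; within the scatter), in no particular direction. Compound 3 is expected to give 1.15 ug/mL, within a range from 0.6 ug/mL to 2.3 ug/mL.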

Compound 3, half-maximal inhibitory concentration: 1.27 ug/mL
Compound 3: middle estimate off by 1.1-fold (0.04 log units), on the low side; measured number inside the range.
By their numbers in this assay, from the lowest: compounds 1, 2 and 3 (each within the scatter of the next).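

In this assay, fluoro in place of hydrogen gives a 1.1-fold higher number from compound 2 to compound 3 (0.03 log units; within the scatter) and fluoro in place of trifluoromethyl gives a 1.2-fold higher number from compound 1 to compound 3 (0.06 log units; within the scatter) so both steps to the new compound stay as small as the earlier one. Within the data shown here, this place on the six-membered aromatic ring, para to a large group, has now held three different occupants rather than two: hydrogen, a single fluorine atom and trifluoromethyl, and compound 1, compound 2 and compound 3 cannot be told apart on this read-out, with no compound among them going against that. Nothing measured here offers a reason why these three groups read alike, so the result stands as an observation and not as an explanation.

All three occupants are small and closely related, so this flat result covers only a narrow part of what could sit at this place. An amine, a carboxylic acid or a longer alkyl chain at the same carbon remains an open case, as does fluoro on a different carbon of the same ring, and any of these could either read alike or step beyond the scatter.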